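The source may report more compounds than this note shows. Statements on the series, on what has been measured and on what is new or still open speak of the compounds shown alone.

In a functional assay on SK-MEL-5 cells (Homo sapiens) (on this read-out higher numbers stand for weaker inhibition of growth and lower numbers for stronger inhibition of growth), compound 1 `Cc1cc(C)c2c(O)cc(-c3ccc(Cl)cc3)nc2n1` gives 14100 nM as its reading. For the measured compounds named here, this is the lower of the two numbers so far, and compound 2 `COc1ccc(-c2cc(O)c3cccnc3n2)cc1` sits higher at 34700 nM on the same scale, a gap beyond the usual scatter. The next structure, compound 3 `COc1ccc(-c2cc(O)c3c(C)cc(C)nc3n2)cc1`, keeps the core of compound 1 and changes one group, with methoxy in place of chloro on an aromatic carbon of the ring that carries it. Going by the values given here, no pair of measured compounds differs in only one place, so the size of this swap cannot be read directly. Compound 2 also carries methoxy and gives 34700 nM in this assay as a weak hint toward weaker inhibition. The expected change, a 1.6-fold higher number from compound 1 to compound 3 (0.19 log units; within the scatter) in size, stays within the scatter. Compound 3 is estimated at 22000 nM with an expected range from 9000 nM to 50000 nM in this read-out.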

Compound 3, concentration for 50% growth inhibition: 17800 nM
Compound 3: the middle estimate sits 1.2-fold (0.09 log units) above what was measured, and the stated range covers the measured number.
By their numbers in this assay, from the lowest: compounds 1, 3 and 2 (each within the scatter of the next, the first and the last beyond it).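

this assay now gives the first direct reading of this swap: methoxy in place of chloro on an aromatic carbon, para to a large group, amounts to a 1.3-fold higher number from compound 1 to compound 3 (0.10 log units; within the scatter), and this step lies within the scatter. On the core of compound 1, this read-out therefore does not separate the two groups, even though methoxy brings one more heavy atom and a hydrogen-bond acceptor that chloro does not count. No available measurement speaks to why the two groups read alike.

The compounds shown leave open whether a different group at this place, such as an amine, a carboxylic acid or a longer chain like butoxy, would move the number beyond the scatter. They also leave open whether the methoxy-for-chloro swap would read the same on another core.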